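The compounds below may be only part of what the source reports. "The series", "measured", "known", "first", "only" and "open" are said of these compounds alone.

Compound 1, `CCOC(=O)C1(Cc2ccccc2)CN(c2ccccc2)Cc2nnn(Cc3ccc(F)cc3)c21`, gives >= 100000 nM in an ADME assay on HEL cells (Homo sapiens) for cytotoxicity, read by microscopy, with a stated time of 3 days; a higher number here means that more compound is tolerated, a lower number that less compound is tolerated; this value is a limit of the assay and not a number.
Compound 2, `CCOC(=O)C1(Cc2ccccc2)CN(c2ccccc2)Cc2nnn(Cc3cccc(F)c3)c21`, gives >= 100000 nM in this assay; this too is a limit of the assay.
Compound 3, `Fc1ccc(Cn2nnc3c2CCN(c2ccc(C(F)(F)F)cc2)C3)cc1`, gives 100000 nM in this assay.

Compounds 1 and 2 share a core and differ only in the change (3-fluorophenyl in place of 4-fluorophenyl on a saturated chain carbon bound to an aromatic nitrogen). The step between them is a step that the two limits leave unreadable from compound 1 to compound 2, and it stays unreadable owing to the limit of >= 100000 nM in this assay, at which 2 of the 3 values shown sit. Compound 3 stands on a different core; how its core differs from the core of compound 1 is not broken down here. It is the only one of the three whose result in this assay is a number rather than a limit.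

Compound 4, `Fc1cccc(Cn2nnc3c2CCN(c2ccc(C(F)(F)F)cc2)C3)c1`, has not yet been measured in this assay. It differs from compound 3 by 3-fluorophenyl in place of 4-fluorophenyl on a saturated chain carbon bound to an aromatic nitrogen, the same kind of change as that from compound 1 to compound 2, made at the same kind of place on the other core. Within the data shown here, since the step from compound 1 to compound 2 cannot be read in size, the only guide for compound 4 is the value of compound 3, 100000 nM. Compound 4 is therefore expected to stay close to compound 3, with an expected step of no change at the digits printed from compound 3 to compound 4 (within the scatter). Compound 4 is estimated at 100000 nM, between 50000 nM and 200000 nM, with a fair chance that the assay again reports only a limit.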

Compound 4, minimum cytotoxic concentration: 100000 nM
Estimate against measurement, compound 4: no gap at the digits printed; the measured number falls inside the stated range.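

In this assay, the swap of 4-fluorobenzyl for 3-fluorobenzyl on the core of compound 3 gives no change at the digits printed from compound 3 to compound 4 (within the scatter), so on this core the two isomers cannot be told apart. The same swap on the core of compound 1 offers no size to set beside this result, and the two cores cannot be compared for this change, because compound 1 and compound 2 both give a limit of the assay rather than a number: the limit of >= 100000 nM in this assay, at which 2 of the 4 values shown sit. The result therefore fits the idea that the change carries across the two cores without effect on tolerated concentration, but it rests on a single readable pair and does not show that the change behaves alike on both cores, nor that it would do so on any other.

The compounds shown leave open whether any group on this series lowers the tolerated concentration in this assay, since every fluorobenzyl variant shown has fluorine as its only ring substituent. An amine in place of the trifluoromethyl of compound 3, or a carboxylic acid in place of the ethyl ester of compound 1, would test this on each core.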